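Nitro substitution on a dithiazole thione series, antiproliferative screen

The compounds below may be only part of what the source reports. "The series", "measured", "known", "first", "only" and "open" are said of these compounds alone.

Measured so far:
compound 1 `O=[N+]([O-])c1ccc(-c2nss/c2=N\c2ccccc2)cc1`, 0%
compound 2 `S=c1ssnc1-c1ccccc1`, 0%

In a functional assay on MDA-MB-231 cells (Homo sapiens) for antiproliferative activity, read by MTT assay, with a stated time of 72 h, tested at 10 uM (on this read-out higher numbers stand for more inhibition at the one concentration tested (going by the name of the read-out) and lower numbers for less inhibition), compound 1 gives 0%. In the same screen compound 2 gives 0%, level with compound 1 at the digits shown; the two values lie within the scatter of each other, so no order between them is claimed.

Compound 3 `O=[N+]([O-])c1ccc(-c2nssc2=S)cc1` is the next member to be measured. It differs from compound 2 in one place: nitro in place of hydrogen on an aromatic carbon. Among the compounds with values here, no step between measured compounds bears on this change, so nothing is known of what it does here. Since both compound 1 and compound 2 show no inhibition, no step beyond the scatter is expected from compound 2 to compound 3; the expected step is no change at the digits printed from compound 2 to compound 3 (within the scatter). For compound 3 the estimate is 0%, expected to fall between 0% and 12%.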

Compound 3, a percentage reported as inhibition, at one concentration (the size of the read-out at that concentration, not a potency): 0%
Beside the measured number, compound 3's estimate shows no gap at the digits printed; low and high end bracket the measured number.
By their numbers in this assay, from the lowest: compounds 1, 2 and 3 (each within the scatter of the next).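

In this assay, within the data shown here, the step of no change at the digits printed from compound 2 to compound 3 (within the scatter) is the first single-place comparison. It shows that nitro in place of hydrogen on this aromatic carbon, para to a group of 6 heavy atoms, does not bring inhibition into view. With no inhibition on either side, the step cannot rank nitro against hydrogen at this position. No supporting data explain this outcome.

On these data alone, whether an amine or a carboxylic acid on this same aromatic carbon would give measurable inhibition stays open. So does whether any substituent at this position can do so.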